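The compounds below may be only part of what the source reports. "The series", "measured", "known", "first", "only" and "open" are said of these compounds alone.

In a functional assay on MCF7 cells (Homo sapiens) for inhibition, read by MTT assay, with a stated time of 48 h (a lower number here means a stronger inhibitor, a higher number a weaker inhibitor), three compounds on one shared core have been measured. Here compound 1 `CCOC(=O)C1=C(N/N=C(/C#N)C(=O)OCC)Nc2[nH]nc(C)c2C1c1ccc(N(C)C)cc1` gives 35600 nM and compound 2 `CCOC(=O)C1=C(N/C=N/c2nnc(S(N)(=O)=O)s2)Nc2[nH]nc(C)c2C1c1ccc(N(C)C)cc1` gives 34500 nM while compound 3 `CCOC(=O)C1=C(N/N=C(/C(=O)Br)c2ccc(Br)cc2)Nc2[nH]nc(C)c2C1c1ccc(N(C)C)cc1` gives 61300 nM in the same test. Compound 3 thus stands level with the other two: the steps to it are a 1.7-fold higher number from compound 1 to compound 3 (0.24 log units; within the scatter) and a 1.8-fold higher number from compound 2 to compound 3 (0.25 log units; within the scatter) and neither leaves the scatter.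

The change to compound 4 `CCOC(=O)C1=C(N/C=N/c2ccccn2)Nc2[nH]nc(C)c2C1c1ccc(N(C)C)cc1` is a group of 8 heavy atoms (6 carbon, 2 nitrogen; one six-membered aromatic ring with 1 hetero atom) in place of a group of 12 heavy atoms (8 carbon, 1 nitrogen, 1 oxygen, 2 bromine; one six-membered aromatic ring of carbon only), on an amine nitrogen and it falls on the same amine nitrogen that varies across the three measured compounds. It takes out a six-membered aromatic ring of carbon only and brings in a six-membered aromatic ring with 1 hetero atom. The remaining measured step at this nitrogen is a 1.0-fold lower number from compound 1 to compound 2 (0.01 log units; within the scatter) and it too stays within the scatter, even though it brings in a five-membered aromatic ring with 3 hetero atoms. None of the three measured compounds carries the new group, yet on these three steps no shift beyond the scatter is expected in this assay for this exchange. For the measured compounds named here, the expected change is a 1.5-fold lower number from compound 3 to compound 4 (0.19 log units; within the scatter) and this would be no real step. For compound 4 the estimated value is 40000 nM with 18000 nM to 85000 nM as its expected range.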

Compound 4, half-maximal inhibitory concentration: 37300 nM
For compound 4 the middle estimate is 1.1-fold (0.03 log units) above the measured one; the measured number falls inside the stated range.
By their numbers in this assay, from the lowest: compounds 2, 1, 4 and 3 (each within the scatter of the next).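

In this assay, the exchange of pyridin-2-yl for 5-sulfamoyl-1,3,4-thiadiazol-2-yl on a double-bonded nitrogen gives a 1.1-fold higher number from compound 2 to compound 4 (0.03 log units; within the scatter). For the compounds shown here, this is the first comparison to change only the ring on that nitrogen while the link to the shared core stays the same, and it shows that this swap of one aromatic ring for another leaves the number within the scatter. The broader exchanges on the amine nitrogen also stay within the scatter, at a 1.6-fold lower number from compound 3 to compound 4 (0.22 log units; within the scatter) and a 1.0-fold higher number from compound 1 to compound 4 (0.02 log units; within the scatter), so across these four compounds neither the bromine-bearing group nor the group with no ring stands apart from the pyridine-bearing compound, and no evidence is available to explain this flat result.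

The compounds shown leave open whether any group on this amine nitrogen can move the number beyond the scatter, since all four carry fairly large groups there and a plain amine or a short carbon chain is not among them. They also leave open whether changes elsewhere on the shared core, such as a carboxylic acid in place of the ethyl ester, would matter more than changes at this position.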